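The compounds below may be only part of what the source reports. "The series", "measured", "known", "first", "only" and "open" are said of these compounds alone.

Two measured compounds share one core. Compound 1 `Cc1nc2c(cnn2-c2ccccc2)c(=O)n1C1CCCCCC1` carries a cycloheptyl group on an aromatic nitrogen, and in an in vitro functional assay on cells for antagonist activity at metabotropic glutamate receptor 1 (Homo sapiens), read by FLIPR and calcium flux (on this read-out higher numbers stand for weaker inhibition and lower numbers for stronger inhibition), compound 1 gives 760 nM. Compound 2 `Cc1nc2c(cnn2-c2ccccc2)c(=O)n1N1CCCCC1` carries a piperidin-1-yl group in that place, and in this assay compound 2 gives 91 nM. Among the compounds with values here, the step of an 8.4-fold lower number from compound 1 to compound 2 (0.92 log units; beyond the scatter) is the only measured step, and it leaves compound 2 with the lowest of the two numbers, the stronger inhibitor of the pair. Compound 3 `Cc1nc2c(cnn2-c2ccccc2)c(=O)n1N1CCCCCC1` is not yet measured. It differs from compound 2 in one place: azepan-1-yl in place of piperidin-1-yl on an aromatic nitrogen. Within the data shown here, the one measured step swaps a cycloheptyl for a piperidin-1-yl, which changes both the ring size and the atom in the ring at once, so it is only a weak guide to a change of ring size alone. The step of a 1.6-fold higher number from compound 2 to compound 3 (0.22 log units; within the scatter) is therefore expected to be small, possibly a slightly higher number, and possibly none beyond the scatter. Compound 3 is estimated to give 150 nM in this assay, within a range from 40 nM to 600 nM.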

Compound 3, half-maximal inhibitory concentration: 240 nM
Estimate against measurement, compound 3: 1.6-fold (0.20 log units) below; measured number inside the range.
By their numbers in this assay, from the lowest: compound 2; then compound 3; then compound 1.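

Ring size at this position matters even when the ring stays joined through its nitrogen: going from piperidin-1-yl to azepan-1-yl gives a 2.6-fold higher number from compound 2 to compound 3 (0.42 log units; beyond the scatter) in this assay and so moves the number away from that of compound 2, the lowest of the three. Keeping the seven-membered ring and changing only the atom that joins it to the core gives a 3.2-fold lower number from compound 1 to compound 3 (0.50 log units; beyond the scatter) as the second new step, which shows that this atom alone also shifts the number, something the earlier pair could not show because ring size and joining atom changed together there. Nothing measured here accounts for either step.

With only six- and seven-membered rings in hand, these compounds leave open whether a smaller ring such as pyrrolidin-1-yl would give a lower or a higher number than compound 2. They also leave open how the number would respond to a second hetero atom in the six-membered ring, as in morpholin-4-yl, or to an open-chain group such as dimethylamino in the same place.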